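A few compounds are considered here, and "the series" means these few. Any claim that something is new, unique, unknown or untested is made for them only; others in the source may bear on it.

Compound 2 `CCCOC(=O)/C=C/c1ccc(NC(=O)C2(NC(=O)c3ccc4c(C5CCCC5)c(-c5ncc(Cl)cn5)n(C)c4c3)CCC2)cc1OCC` carries a propyl ester at the end of the unsaturated chain attached to the shared core. In an ADME assay (intestine, Rattus norvegicus) for pharmacokinetics, using microsomes (a higher number here means that the compound lasts longer, a lower number that the compound disappears faster), compound 2 gives > 5 h, which is a limit of the assay rather than a number. Among the compounds with values here, its only measured neighbour is compound 1 `CCOC(=O)/C=C/c1ccc(NC(=O)C2(NC(=O)c3ccc4c(C5CCCC5)c(-c5ncc(Cl)cn5)n(C)c4c3)CCC2)cc1OCC`, which lacks the methyl on the saturated chain carbon two bonds along the chain from an oxygen next to a carbonyl group. In this assay compound 1 gives > 5 h, again a limit and not a number. Within the data shown here, the step that the two limits leave unreadable from compound 1 to compound 2 therefore cannot be read, and the only evidence is the limit of > 5 h in this assay, at which 2 of the 2 values shown sit. Compound 3 `CCOc1cc(NC(=O)C2(NC(=O)c3ccc4c(C5CCCC5)c(-c5ncc(Cl)cn5)n(C)c4c3)CCC2)ccc1/C=C/C(=O)OCC(C)C` lengthens the ester once more: methyl in place of hydrogen on a saturated chain carbon bound to two saturated chain carbons. Among the measured compounds shown here, the single measured step bears directly on this change, but because it is hidden by the limit of > 5 h in this assay, at which 2 of the 2 values shown sit, neither its size nor its direction is known, so no step beyond the scatter can be predicted in either direction for this assay. Compound 3 is therefore expected to reach about 6 h in this assay. Its plausible range is estimated to run from 3 h to 12 h. The implied step is expected to be a step that the limit leaves unreadable from compound 2 to compound 3, most likely ending at a limit again.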

Compound 3, half-life: > 5 h
Compound 3 ended at the assay's limit; the forecaster's own chance of this, stated with the estimate: 70%; the middle value is on the limit's open side.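

In this assay compound 3 gives > 5 h, which is a limit of the assay and not a number. Within the data shown here, no step between compound 1, compound 2 and compound 3 can therefore be read: the limit of > 5 h in this assay, at which 3 of the 3 values shown sit. The compounds shown leave open how long each of the three actually lasts, and whether changing the ester chain alters that at all.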